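The source may hold more compounds than are shown below. What is called first, only, known or untested is meant among the compounds shown, and "the series" means these compounds.

Measured compounds:
compound 1, `Cc1ccc(S(=O)(=O)Nc2ccc3c(c2)C(=O)N(Cc2ccccc2F)C3=O)cc1`: 195000 nM
compound 2, `Cc1ccc(S(=O)(=O)Nc2ccc3c(c2)C(=O)N(CCOc2cccc(O)c2)C3=O)cc1`: 55600 nM

In an assay on isolated protein for inhibition of lysosomal alpha-glucosidase (Rattus norvegicus), read by colorimetric assay (a lower number here means a stronger inhibitor, a higher number a weaker inhibitor), compound 2 gives the lowest of the two numbers seen so far; its nearest neighbour is compound 1, and the step of a 3.5-fold lower number from compound 1 to compound 2 (0.54 log units; beyond the scatter) lies beyond the scatter. The next compound, compound 3 `Cc1ccc(S(=O)(=O)Nc2ccc3c(c2)C(=O)N(CCCCBr)C3=O)cc1`, is not yet measured. Its change from compound 2 is 2-bromoethyl in place of 3-hydroxyphenoxy on a saturated chain carbon, two bonds along the chain from an amide-type nitrogen in a ring. Going by the values given here, only one measured step bears on this position of the chain: a 3.5-fold lower number from compound 1 to compound 2 (0.54 log units; beyond the scatter), where the (3-hydroxyphenoxy)methyl group brought a modest gain over 2-fluorophenyl. Compound 3 carries neither of those groups, only the bromoalkyl chain with no ring. With the group that marked the only gain in the series removed, the expectation is a step back towards, or somewhat past, the number of compound 1, though a single step is a thin basis and the direction is not certain. The expected step is a 2.7-fold higher number from compound 2 to compound 3 (0.43 log units; beyond the scatter). The estimate for compound 3 in this assay is 150000 nM, with a range from 50000 nM to 450000 nM.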

Compound 3, half-maximal inhibitory concentration: > 200000 nM
Compound 3 gave a limit, no number; the forecaster's own chance of this, stated with the estimate: 25%; middle value at least 1.3-fold (0.12 log units) from the limit.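

In this assay compound 3 is read only as a limit of the assay, not as a number: the limit of > 200000 nM in this assay, at which 1 of the 3 values shown sits. With 2-bromoethyl in place of 3-hydroxyphenoxy on a saturated chain carbon, two bonds along the chain from an amide-type nitrogen in a ring, the result is an at least 3.5-fold higher number from compound 2 to compound 3 (0.55 log units; beyond the scatter), so the advantage seen in compound 2 does not carry over to a bromoalkyl chain with no ring. Against compound 1 the comparison gives an at least 1.0-fold higher number from compound 1 to compound 3 (0.01 log units; that floor lies within the scatter), which sets no order between 2-fluorophenyl and 3-bromopropyl at this position, and the two can only be said to share the weak end of the series.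

Which part of the 3-hydroxyphenoxy group accounts for the advantage of compound 2 stays open, as a plain phenoxy or a 3-methoxyphenoxy group would separate the hydroxyl from the aromatic ring and the ether oxygen. Also open, from the compounds shown here alone, is whether an amine or a carboxylic acid in place of the bromine, on the same chain, would bring the reading under the limit and give a number.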